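Furan-2-yl for phenyl: a repeated swap across two cores

A few compounds are considered here, and "the series" means these few. Any claim that something is new, unique, unknown or untested is made for them only; others in the source may bear on it.

Three compounds have been run in a functional assay on T47D cells (Homo sapiens) for cytotoxicity, read by CCK-8 assay and cell counting, with a stated time of 2 days; a lower number here means a stronger inhibitor, a higher number a weaker inhibitor. Compound 1 `Oc1ccc(-c2cc(-c3ccccc3)nc(-c3ccccc3Cl)c2)cc1` gives 5460 nM in this assay. Compound 2 `Oc1ccc(-c2cc(-c3ccco3)nc(-c3ccccc3Cl)c2)cc1` gives 5480 nM. Compound 3 `Oc1cccc(-c2cc(-c3ccccc3)nc(-c3ccc(Cl)cc3)c2)c1` gives 11300 nM, the highest number of the three; its nearest neighbour is compound 2, and compound 1 lies a little further off, both gaps beyond the scatter.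

The change from compound 1 to compound 2 is furan-2-yl in place of phenyl on an aromatic carbon and it made a step of a 1.0-fold higher number from compound 1 to compound 2 (0.00 log units; within the scatter) in this assay: the furan-2-yl group was tolerated with no shift in the number.

Compound 3 and compound 4 `Oc1cccc(-c2cc(-c3ccc(Cl)cc3)nc(-c3ccco3)c2)c1` share the same atoms as compound 1 and compound 2, joined differently; the difference between the two cores is not broken down here. The change from compound 3 to compound 4 is furan-2-yl in place of phenyl on an aromatic carbon. It is the same kind of change as before, not the same: in compound 1 the place is meta to a 2-chlorophenyl group and meta to a 4-hydroxyphenyl group, whereas in compound 3 it is meta to a 3-hydroxyphenyl group and meta to a 4-chlorophenyl group.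

Going by the values given here, with only one prior instance, the expectation for compound 4 rests on the flat step of compound 1 to compound 2 a 1.0-fold higher number from compound 1 to compound 2 (0.00 log units; within the scatter), so the step is estimated at a 1.0-fold lower number from compound 3 to compound 4 (0.01 log units; within the scatter). Compound 4 is therefore expected to give about 11000 nM in this assay, within a range of 5000 nM to 25000 nM.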

Compound 4, half-maximal inhibitory concentration: 10500 nM
Compound 4: middle estimate off by 1.0-fold (0.02 log units), on the high side; the range from low to high includes it.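

In this assay, furan-2-yl in place of phenyl on the second core again leaves the number essentially unchanged, with a 1.1-fold lower number from compound 3 to compound 4 (0.03 log units; within the scatter). Set side by side, the two steps show that the swap carries from the core of compound 1 to the core of compound 3 without a detectable difference: the same change on two cores in this assay, a 1.0-fold higher number (0.00 log units; within the scatter) from compound 1 to compound 2 and a 1.1-fold lower number (0.03 log units; within the scatter) from compound 3 to compound 4, 1.1-fold (0.03 log units) apart, within the scatter of two such steps. Going by these compounds alone, this supports treating furan-2-yl and phenyl as interchangeable at this place on these two cores in this assay, but it rests on only two pairs, both flat, so it does not show that the swap would stay flat on other cores, or that a change with a real effect on the number would carry over in the same way.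

The compounds shown leave open whether any group at this place, next to the ring nitrogen, would move the number at all, for example an amine, a carboxylic acid or a longer alkyl chain in place of the phenyl or furan-2-yl ring. Within the data shown here, they also leave open how the hydroxyl and chlorine positions each contribute to the difference between the two cores, as no pair here changes either one alone.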